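The source may hold more compounds than are shown below. What is called first, only, known or untested is meant among the compounds shown, and "the series" means these compounds.

Values so far in a functional assay on Hs-578T cells (Homo sapiens) for inhibition (a lower number here means a stronger inhibitor of growth, a higher number a weaker inhibitor of growth), are these
compound 1 `O=C(/C=C/c1cccc(O)c1)c1cccc(-n2cc(-c3ccccc3)[nH]c2=O)c1` gives 6140 nM
compound 2 `COc1cc(/C=C/C(=O)c2cccc(-n3cc(-c4ccccc4)[nH]c3=O)c2)cc(OC)c1OC` gives 3410 nM

Compound 2 stands at the same level as compound 1, since the two numbers cannot be told apart given the usual scatter, and the pair offers no ranking.

The next compound is compound 3 `COc1cc(/C=C/C(=O)c2cccc(-n3cc(-c4cc(OC)c(OC)c(OC)c4)[nH]c3=O)c2)cc(OC)c1OC` and it keeps the rest of compound 2 while changing one group: 3,4,5-trimethoxyphenyl in place of phenyl on an aromatic carbon with 3,4,5-trimethoxyphenyl in place of phenyl on an aromatic carbon of the five-membered aromatic ring with 2 nitrogen.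

Among the measured compounds shown here, no measured step covers this change, so the data set neither its size nor its direction. In this assay the expectation is therefore no step beyond the scatter, with compound 2 at 3410 nM as the only anchor. The expected step is a 1.1-fold lower number from compound 2 to compound 3 (0.06 log units; within the scatter) and the range around it is kept wide. For compound 3 the estimate is 3000 nM with 800 nM to 10000 nM as the expected range.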

Compound 3, concentration for 50% growth inhibition: "not active" (no number reported)
The entry for compound 3 holds no number; there is nothing to compare the estimate with.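

In this assay, among the compounds shown here, compound 3 is recorded as not active without a number, so no step from compound 2 to compound 3 can be read. The compounds shown leave open how large any change from phenyl to 3,4,5-trimethoxyphenyl is in this series. No data shown account for the result of compound 3.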